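Compound 3: a rearranged isomer of compound 2

A few compounds are considered here, and "the series" means these few. Any claim that something is new, unique, unknown or untested is made for them only; others in the source may bear on it.

compound 1 `C=CCc1ccc(OCc2cn(-c3ccccc3Cl)nn2)c(O)c1` gives 58.3%
compound 2 `C=CCc1ccc(OCc2cn(-c3ccc(OC)cc3)nn2)c(O)c1` gives 38.8%

In a functional assay on MCF7 cells (Homo sapiens) for inhibition, read by MTT assay, with a stated time of 72 h, tested at 30 uM (a lower number here means less inhibition of growth, a higher number more inhibition of growth at the concentration tested), compound 2 holds the lower of the two numbers, and compound 1 lies above it by more than the scatter. The next compound is compound 3 `C=CCc1ccc(OCc2cn(-c3ccccc3CO)nn2)c(O)c1`, which has the same atoms as compound 2, joined differently. The change is 2-(hydroxymethyl)phenyl in place of 4-methoxyphenyl on an aromatic nitrogen and it puts 2-(hydroxymethyl)phenyl in place of 4-methoxyphenyl on an aromatic nitrogen.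

Among the compounds with values here, one measured step bears on this: a number 19.5 percentage points lower from compound 1 to compound 2 (beyond the scatter) is a modest step, and it exchanges the group on that same nitrogen. Compound 3 resembles compound 1 in carrying a 2-substituted phenyl group, and compound 1 reaches 58.3% with its 2-chlorophenyl. Within the data shown here, no compound with a hydroxymethyl group has been measured, so only part of that difference is expected to carry over. A rise is therefore expected, estimated as a number 11.2 percentage points higher from compound 2 to compound 3 (beyond the scatter). In this assay the estimate for compound 3 is 50%, with 32% to 66% as its expected range.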

Compound 3, percent growth inhibition at one concentration: 34.5%
Compound 3: middle estimate off by 15.5 percentage points, on the high side; the range from low to high includes it.
By their numbers in this assay, from the lowest: compounds 3 and 2 (each within the scatter of the next); then compound 1.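

In this assay, the exchange on the aromatic nitrogen of the five-membered ring gives a number 4.3 percentage points lower from compound 2 to compound 3 (within the scatter), so 4-methoxyphenyl and 2-(hydroxymethyl)phenyl cannot be told apart here, even though only the entering group carries a hydrogen-bond donor. Replacing chloro with hydroxymethyl on the phenyl ring gives a number 23.8 percentage points lower from compound 1 to compound 3 (beyond the scatter), so among these three compounds the higher number of compound 1 goes with its chloro group and not with a 2-substituted phenyl group as such. Nothing given here explains either step.

Because compound 1 and compound 2 differ both in the group and in where it sits on the phenyl ring, the compounds shown do not separate the contribution of the chloro group from that of its place. Going by these compounds, it also remains open whether a bromo group, an amine or a carboxylic acid on that phenyl ring would stand with compound 1 or with compound 2 and compound 3.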